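Piperidine amine series: indanyl to phenylethyl on compound 2

This account rests on a few compounds, and the source may have more. Where it says the series, first, only, none or still open, it means among the compounds named here.

Working notes on three measured members and one open position. Compound 1 `c1ccc(C2CCCCN2C2CCN(CCCc3c[nH]c4ccc(-n5cnnc5)cc34)CC2)cc1` gives 65% in a functional assay on CHO cells for activation of 5-hydroxytryptamine receptor 1D (Homo sapiens), read by GTPgammaS binding; a higher number here means a larger maximal response, a lower number a smaller maximal response. Compound 2 `c1ccc2c(c1)CCC2NC1CCN(CCCc2c[nH]c3ccc(-n4cnnc4)cc23)CC1` gives 68% in this assay, and compound 3 `CC(=O)Nc1ccc([C@H](C)NCC2CCN(CCCc3c[nH]c4ccc(-n5cnnc5)cc34)CC2)cc1` gives 99% in this assay. Of the three numbers compound 2 stands second highest; its gap to compound 1 lies within the scatter, so no order between the two can be read, while its gap to compound 3 lies beyond the scatter, with compound 3 the higher of the pair.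

Compound 4 `C[C@@H](NC1CCN(CCCc2c[nH]c3ccc(-n4cnnc4)cc23)CC1)c1ccccc1` is the open position. Relative to compound 2 it differs in one place: 1-phenylethyl in place of 2,3-dihydro-1H-inden-1-yl on an amine nitrogen. Among the measured compounds shown here, no pair of measured compounds shows this change on its own, so its size cannot be read from the series. Compound 3 also carries a 1-arylethyl on its amine and gives 99%, but it differs from compound 2 in further places, so it serves only as a loose pointer. The step is expected to be modest and upward, a number 8 percentage points higher from compound 2 to compound 4 (within the scatter), close to the edge of the scatter. Compound 4 is estimated at 76%, with a range from 58% to 94%.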

Compound 4, largest response reached (reported as efficacy), in percent of the reference or control that the assay uses: 90%
Beside the measured number, compound 4's estimate is 14 percentage points below it; the range from low to high includes it.
By their numbers in this assay, from the lowest: compounds 1 and 2 (each within the scatter of the next); then compounds 4 and 3 (each within the scatter of the next).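

In this assay, among the compounds shown here, the change from 2,3-dihydro-1H-inden-1-yl to 1-phenylethyl on the amine nitrogen gives a number 22 percentage points higher from compound 2 to compound 4 (beyond the scatter), the first reading of a single-place change. It shows that the group on this nitrogen can shift the maximal response beyond the scatter, and that the five-membered non-aromatic ring of the 2,3-dihydro-1H-inden-1-yl group is not needed for a high response in this pair. No measurement at hand accounts for the step, which also brings in a defined stereocentre and one heavy atom fewer.

From the compounds shown here alone, it remains open whether the step belongs to the loss of the five-membered ring or to the particular stereocentre, a question that the opposite enantiomer of 1-phenylethyl or a plain benzyl on the same nitrogen would bear on. Going by these compounds, it is also open how far the response at this position follows the distance of the phenyl ring from the nitrogen, which a 2-phenylethyl group would test.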